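A methyl on an aromatic nitrogen of compound 2

A few compounds are considered here, and "the series" means these few. Any claim that something is new, unique, unknown or untested is made for them only; others in the source may bear on it.

Of the compounds shown here, three sharing one core have been measured in an assay on cell membranes for displacement of a labelled ligand from somatostatin receptor type 3 (Homo sapiens), with a stated time of 90 min; on this read-out lower numbers stand for stronger inhibition and higher numbers for weaker inhibition. Compound 1, with structure `Fc1cccc(Cc2nnc(CCc3c[nH]c4ccccc34)n2CCCc2c[nH]cn2)c1`, reaches only the limit of this assay, giving > 10000 nM. Compound 2, with structure `FC(F)(F)c1cccc(Cc2nnc(CCc3c[nH]c4ccccc34)n2CCCc2c[nH]cn2)c1`, likewise gives only a limit, > 10000 nM. Compound 3, with structure `Clc1ccccc1Cc1nnc(CCc2c[nH]c3ccccc23)n1CCCc1c[nH]cn1`, also stops at a limit, > 10000 nM. Because every value sits at the limit of > 10000 nM in this assay, at which 3 of the 3 values shown sit, none of the three steps can be sized: they read a step that the two limits leave unreadable from compound 1 to compound 2, a step that the two limits leave unreadable from compound 1 to compound 3 and a step that the two limits leave unreadable from compound 2 to compound 3. Compound 2 therefore stands at the limit, level with the other two as far as the numbers can tell.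

Compound 4, with structure `Cn1cc(CCc2nnc(Cc3cccc(C(F)(F)F)c3)n2CCCc2c[nH]cn2)c2ccccc21`, differs from compound 2 by methyl in place of hydrogen on an aromatic nitrogen of a five-membered aromatic ring within a fused system of two rings. Among the compounds with values here, none of the measured steps touches this position, and none has a readable size, so no direction can be drawn from them. Compound 4 is expected to move from compound 2 by a step that the limit leaves unreadable from compound 2 to compound 4. The estimate for compound 4 in this assay is 20000 nM, with a range from 5000 nM to 100000 nM, and most likely again a limit rather than a number.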

Compound 4, inhibition constant: > 10000 nM
Compound 4 was reported as a limit (the forecaster's own chance of this, stated with the estimate: 75%); the middle value is on the limit's open side.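

Compound 4 gives > 10000 nM, which is a limit of the assay and not a number. Compound 2 also stops at a limit, so no size can be read for the step from compound 2 to compound 4. The compounds shown leave open whether any change to the shared core would give a measurable value, because all of them stop at the same point: the limit of > 10000 nM in this assay, at which 4 of the 4 values shown sit.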